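Pyrazolopyrimidine series: aryl substituent variation at adenosine receptor

The source may report more compounds than this note shows. Statements on the series, on what has been measured and on what is new or still open speak of the compounds shown alone.

Measured so far:
compound 1, `Cn1c(=O)[nH]c2c(cnn2-c2ccccc2Br)c1=N`, 6%
compound 2, `Cn1c(=O)[nH]c2c(cnn2-c2cccc([N+](=O)[O-])c2)c1=N`, 2%

In an assay on membranes from brain for binding affinity to adenosine receptor A1 (Rattus norvegicus), read by radioligand binding, tested at 20 uM (on this read-out lower numbers stand for less inhibition and higher numbers for more inhibition at the one concentration tested (going by the name of the read-out)), compound 1 gives 6% and compound 2 gives 2%. The two numbers lie within the scatter of each other, so compound 2 is not separated from compound 1 on this read-out; both show little inhibition.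

Compound 3, `Cn1c(=O)[nH]c2c(cnn2-c2cccc(Br)c2)c1=N`, remains to be measured. It differs from compound 2 by bromo in place of nitro on an aromatic carbon. Among the compounds with values here, no step between measured compounds covers this change; with both measured numbers near the bottom of the read-out, no step beyond the scatter is expected for the change from compound 2 to compound 3. Compound 3 is expected at 5%, range -5% to 15%, which means an expected step of a number 3 percentage points higher from compound 2 to compound 3 (within the scatter).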

Compound 3, a percentage reported as inhibition, at one concentration (the size of the read-out at that concentration, not a potency): 40%
Beside the measured number, compound 3's estimate is 35 percentage points below it; the whole stated range lies below it.
By their numbers in this assay, from the lowest: compounds 2 and 1 (each within the scatter of the next); then compound 3.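

In this assay, bromo in place of nitro on an aromatic carbon, meta to a large group, gives a number 38 percentage points higher from compound 2 to compound 3 (beyond the scatter) on the shared core. This position is therefore not silent to the group it carries, which compounds 1 and 2 alone could not show. Nothing available bears on the reason for this step.

Still open, on these data alone, is whether the step belongs to bromo in particular or would also appear with other groups at this place, such as chloro, methoxy or an amine. A single concentration also leaves the potency of compound 3 open.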